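The compounds below may be only part of what the source reports. "The series", "measured", "known", "first", "only" and "open" are said of these compounds alone.

Of the compounds shown here, two of a shared core have been measured so far. Compound 1 `C=Cc1cccc(C(=O)NCN2CCC(c3cccc[n+]3[O-])CC2)c1` and compound 2 `Cc1ccc(C(=O)NCN2CCC(c3cccc[n+]3[O-])CC2)cc1C(F)(F)F` carry the same core and differ only in the substituents on the aromatic ring of the amide. In a functional assay on HEK293 cells for agonist activity at D(4) dopamine receptor (Homo sapiens), read by FLIPR (a higher number here means a larger maximal response, a lower number a smaller maximal response), compound 1 gives 63%. In this assay compound 2 gives 59%. The two values sit within the usual scatter of each other, so neither compound can be said to give a larger or a smaller maximal response than the other.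

Compound 3 `Cc1ccc(C(=O)NCN2CCC(c3cccc[n+]3[O-])CC2)cc1C` has not yet been measured. It differs from compound 2 in one place: methyl in place of trifluoromethyl on an aromatic carbon. Going by the values given here, no step between two measured compounds describes this exchange, so the expectation rests on the narrow spread between compound 1 and compound 2 alone. A methyl in place of a trifluoromethyl on the aromatic carbon is expected to leave the maximal response in this assay essentially where compound 2 stands, with a step of a number 1 percentage points higher from compound 2 to compound 3 (within the scatter) that is not expected to exceed the scatter. Compound 3 is therefore estimated to give 60% in this assay, between 45% and 75%.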

Compound 3, largest response reached (reported as efficacy), in percent of the reference or control that the assay uses: 65%
Compound 3: middle estimate off by 5 percentage points, on the low side; the range from low to high includes it.
By their numbers in this assay, from the lowest: compounds 2, 1 and 3 (each within the scatter of the next).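

The exchange of trifluoromethyl for methyl, on the aromatic carbon ortho to a methyl group, gives in this assay a number 6 percentage points higher from compound 2 to compound 3 (within the scatter), so at this position a group of one heavy atom and a group of four heavy atoms cannot be told apart by maximal response. The exchange of 3-vinylphenyl for 3,4-dimethylphenyl on the carbonyl carbon gives a number 2 percentage points higher from compound 1 to compound 3 (within the scatter), so this larger change to the aromatic group of the amide also leaves the response within the scatter. Nothing available here bears on why these exchanges leave the maximal response unresolved, and the steps offer no explanation of their own.

The compounds shown leave open whether any group at this aromatic carbon can move the response beyond the scatter, since an amine, a hydroxyl group or a carboxylic acid in this place would be a different kind of exchange from the one between methyl and trifluoromethyl. They also leave open whether a plain hydrogen here would give a response that can be told apart from that of compound 3 in this assay.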